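The source may hold more compounds than are shown below. What is called first, only, known or untested is meant among the compounds shown, and "the series" means these compounds.

Measured so far in an assay on isolated protein for inhibition of Ephrin type-A receptor 2 (Homo sapiens), read by thermal shift assay, tested at 10 uM; on this read-out higher numbers stand for stronger stabilisation of the target against heat and lower numbers for weaker stabilisation of the target:
compound 1 `Cn1nc(C(C)(C)C)cc1NC(=O)Nc1cc(C(F)(F)F)cc(C(F)(F)F)c1` gives 0.4 degrees C
compound 2 `Cn1nc(-c2ccccc2)cc1NC(=O)Nc1cc(C(F)(F)F)cc(C(F)(F)F)c1` gives 0.9 degrees C
compound 3 `Cn1nc(C(C)(C)C)cc1NC(=O)Nc1cc(F)cc(F)c1` gives 0.4 degrees C

Compound 1 and compound 2 differ in one place, (phenyl in place of tert-butyl on an aromatic carbon), and this change made a step of a number 0.50 degrees C higher from compound 1 to compound 2 (within the scatter). Compound 3 stands level with compound 1 at the digits reported, and its value against compound 2 also lies within the scatter of this assay; the difference between the core of compound 3 and the core of compound 1 is not broken down here. Compound 4 `Cn1nc(-c2ccccc2)cc1NC(=O)Nc1cc(F)cc(F)c1` has not yet been measured in this assay. Within the data shown here, it differs from compound 3 by the same change as the one between compound 1 and compound 2, (phenyl in place of tert-butyl on an aromatic carbon), on a place described in the same words. Because compound 3 gives 0.4 degrees C and because the same change gave a number 0.50 degrees C higher from compound 1 to compound 2 (within the scatter), the step from compound 3 to compound 4 is expected to be a number 0.50 degrees C higher from compound 3 to compound 4 (within the scatter). Compound 4 is therefore estimated at 0.9 degrees C, with the measurement expected to fall between -0.3 degrees C and 2 degrees C.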

Compound 4, shift of the target's melting temperature: 0.3 degrees C
Compound 4: middle estimate off by 0.60 degrees C, on the high side; measured number inside the range.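

In this assay, phenyl in place of tert-butyl on an aromatic carbon gave a number 0.50 degrees C higher from compound 1 to compound 2 (within the scatter) on one core and a number 0.10 degrees C lower from compound 3 to compound 4 (within the scatter) on the other. The two results can be set side by side and do not differ by more than repeated measurements would allow: the same change on two cores in this assay, a number 0.50 degrees C higher (within the scatter) from compound 1 to compound 2 and a number 0.10 degrees C lower (within the scatter) from compound 3 to compound 4, 0.60 degrees C apart, within the scatter of two such steps This shows no sign that the two cores respond differently to the change, but it does not show that the change carries over unaltered, as neither step stands clear of the scatter and a small real difference between the cores would go unseen here.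

The compounds shown leave open whether another group on that aromatic carbon, such as an amine, a carboxylic acid or a longer chain, would give a step beyond the scatter in this assay. They also leave open whether a nitrile in place of trifluoromethyl or fluorine on the other ring would do so.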